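Swapping Methyl for Fluoro on a Shared Core

A few compounds are considered here, and "the series" means these few. Any claim that something is new, unique, unknown or untested is made for them only; others in the source may bear on it.

Two close relatives have so far been measured in an ADME assay on Raji cells (Homo sapiens) for cytotoxicity, with a stated time of 72 h; on this read-out higher numbers stand for an effect only at larger amounts of compound and lower numbers for an effect already at smaller amounts. Compound 1, `CSc1ccc(NC(=O)Nc2cc(C)nc3ccccc23)cc1`, sits at the limit of this assay, giving > 25000 nM. Compound 2, `Cc1ccc(NC(=O)Nc2cc(C)nc3ccccc23)cc1`, also sits at the limit, giving > 25000 nM. The step that the two limits leave unreadable from compound 1 to compound 2 therefore cannot be read in size because both values are limits, as the limit of > 25000 nM in this assay, at which 2 of the 2 values shown sit, records.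

Compound 3, `Cc1cc(NC(=O)Nc2ccc(F)cc2)c2ccccc2n1`, is the next candidate. It differs from compound 2 by fluoro in place of methyl on an aromatic carbon. For the measured compounds named here, no measured step bears on this change with a readable size: the only step recorded, from compound 1 to compound 2, is unreadable, and compound 2 itself stands only at a limit, so there is no number to move away from. The expectation is therefore that compound 3 remains at or near that limit, with no step beyond the scatter. Compound 3 is expected to give about 30000 nM in this assay, with a range from 12000 nM to 80000 nM. The expected step that the limit leaves unreadable from compound 2 to compound 3 is thus essentially none.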

Compound 3, half-maximal effective concentration: > 25000 nM
Compound 3: a limit, no number; the forecaster's own chance of this, stated with the estimate: 85%; the middle value lies beyond the limit too.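

Compound 3 also sits at a limit, so the steps to it from compound 1 and from compound 2 cannot be read in size: the limit of > 25000 nM in this assay, at which 3 of the 3 values shown sit.

Left open is whether any group at this place on the shared core would give a readable value in this assay, as none of the compounds shown yields a number there.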